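Adding a Second Methoxy: Compound 4 Weighed Against Compound 3

The compounds below may be only part of what the source reports. "The series", "measured", "known", "first", "only" and "open" are said of these compounds alone.

The measured compounds, each with its half-maximal inhibitory concentration in a functional assay on MCF7 cells (Homo sapiens) for cytotoxicity, read by sulforhodamine B assay, with a stated time of 72 h; on this read-out lower numbers stand for stronger inhibition and higher numbers for weaker inhibition:
Compound 1 `CCS(=O)(=O)Nc1cc(-c2ccc3ncnc(Nc4ccc(F)cc4F)c3c2)cnc1OC` gives 1610 nM.
Compound 2 `CCS(=O)(=O)Nc1cc(-c2ccc3ncnc(Nc4ccc(OC(F)(F)F)cc4)c3c2)cnc1OC` gives 23700 nM.
Compound 3 `CCS(=O)(=O)Nc1cc(-c2ccc3ncnc(Nc4ccc(OC)cc4)c3c2)cnc1OC` gives 1790 nM.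

Compound 3 stands second highest of the three numbers, though its gap to its nearest neighbour is only a 1.1-fold higher number from compound 1 to compound 3 (0.05 log units; within the scatter), which is within the scatter, while its gap to the furthest one is a 13-fold lower number from compound 2 to compound 3 (1.12 log units; beyond the scatter), a large step. Compound 4 `CCS(=O)(=O)Nc1cc(-c2ccc3ncnc(Nc4ccc(OC)c(OC)c4)c3c2)cnc1OC` differs from compound 3 by methoxy in place of hydrogen on an aromatic carbon, placed ortho to a methoxy group and meta to a large group on the same ring.

For the measured compounds named here, no measured step adds a group to this ring; the two steps that touch it swap whole ring substituents. The step from compound 1 to compound 3, a 1.1-fold higher number from compound 1 to compound 3 (0.05 log units; within the scatter), shows this ring tolerating very different groups without change, whereas a 13-fold lower number from compound 2 to compound 3 (1.12 log units; beyond the scatter) shows it can also matter greatly. A second methoxy is a small addition, so for compound 4 a step of a 1.1-fold higher number from compound 3 to compound 4 (0.05 log units; within the scatter) is expected, within the scatter in either direction. Compound 4 is therefore estimated at 2000 nM, with a range of 600 nM to 7000 nM.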

Compound 4, half-maximal inhibitory concentration: 2430 nM
For compound 4 the middle estimate is 1.2-fold (0.08 log units) below the measured one; low and high end bracket the measured number.
By their numbers in this assay, from the lowest: compounds 1, 3 and 4 (each within the scatter of the next); then compound 2.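

In this assay the added methoxy gives a 1.4-fold higher number from compound 3 to compound 4 (0.13 log units; within the scatter) and so leaves the two numbers indistinguishable, the first direct sign that this ring carbon, ortho to a methoxy group, accepts a group in place of hydrogen. The 3,4-dimethoxyphenyl compound also stays level with the 2,4-difluorophenyl one, with a 1.5-fold higher number from compound 1 to compound 4 (0.18 log units; within the scatter) as the printed step. It remains well apart from the 4-(trifluoromethoxy)phenyl compound, with a 9.8-fold lower number from compound 2 to compound 4 (0.99 log units; beyond the scatter) as the step, so the second methoxy does not disturb the gap already seen for compound 3.

From the compounds shown here alone, whether an amine, a carboxylic acid or a longer chain on this same carbon would read alike stays open. No measurement given here speaks to what sets compound 2 apart from the others.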